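Benzoyl in Place of Pyridinoyl on a Weak Core

This account rests on a few compounds, and the source may have more. Where it says the series, first, only, none or still open, it means among the compounds named here.

Compound 1 `O=C(Nc1cc(C(F)(F)F)ccc1N1CCCC1)c1ccncc1` was tested in a functional assay on Jurkat cells (Homo sapiens) for cytotoxicity, read by MTT assay, with a stated time of 48 h (on this read-out lower numbers stand for stronger inhibition and higher numbers for weaker inhibition), and is reported there as "not active" (no number reported), so no single number stands for compound 1. Within the data shown here, compound 2 `O=C(Nc1cc(C(F)(F)F)ccc1NC1CCCCC1)c1ccncc1` in this assay gives 80900 nM, the only measured value in this set. Compound 3 `O=C(Nc1cc(C(F)(F)F)ccc1N1CCCC1)c1ccccc1` differs from compound 1 by phenyl in place of pyridin-4-yl on a carbonyl carbon. Among the measured compounds shown here, no measured step covers this change, and the two measured compounds differ elsewhere, so in this assay a step no larger than the scatter, in no clear direction, is expected, and compound 3 is expected to remain weak. Compound 3 is estimated at 100000 nM, within 30000 nM to 300000 nM, with a fair chance that only a limit is reported.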

Compound 3, half-maximal inhibitory concentration: "not active" (no number reported)
For compound 3 the study gives words and no number, so the estimate cannot be set against anything.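

Compound 1 and compound 3 are both reported in words rather than numbers, so no step can be read between them. From the compounds shown here alone, what phenyl in place of pyridin-4-yl does to potency stays open. No evidence bears on this result.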